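Pyrrolidinyl for dimethylamino on a dibromo hydroxycoumarin core

This account rests on a few compounds, and the source may have more. Where it says the series, first, only, none or still open, it means among the compounds named here.

Compound 1 `CN(C)CCC(=O)c1cc2ccc(O)cc2oc1=O`: 110000 nM
Compound 2 `O=C(CCN1CCCC1)c1cc2ccc(O)cc2oc1=O`: > 200000 nM
Compound 3 `CN(C)CCC(=O)c1cc2cc(Br)c(O)c(Br)c2oc1=O`: > 200000 nM

In an assay on cells for inhibition of Amine oxidase [flavin-containing] A (Homo sapiens), read by fluorescence, spectrophotometry and Amplex Red, with stated times of 60 min and 30 min (on this read-out higher numbers stand for weaker inhibition and lower numbers for stronger inhibition), compound 1 gives 110000 nM. For compound 2 this assay reports only a limit, > 200000 nM. The change between them is pyrrolidin-1-yl in place of dimethylamino on a saturated chain carbon, two bonds along the chain from a carbonyl carbon, and it gave an at least 1.8-fold higher number from compound 1 to compound 2 (0.25 log units; that floor lies within the scatter). For compound 3 this assay again reports only a limit, > 200000 nM; the difference between its core and that of compound 1 is not broken down here. Compound 4 `O=C(CCN1CCCC1)c1cc2cc(Br)c(O)c(Br)c2oc1=O` is not yet measured. It differs from compound 3 by pyrrolidin-1-yl in place of dimethylamino on a saturated chain carbon, two bonds along the chain from a carbonyl carbon, the same change as between compound 1 and compound 2. Since the earlier step did not lower the number, and because compound 3 already sits at the limit of > 200000 nM in this assay, at which 2 of the 3 values shown sit, the step that the limit leaves unreadable from compound 3 to compound 4 is expected to leave compound 4 at or beyond that limit. Compound 4 is expected to give about 300000 nM, most likely reported only as a limit.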

Compound 4, half-maximal inhibitory concentration: 155000 nM
For compound 4 the middle estimate is 1.9-fold (0.29 log units) above the measured one; the measured number falls inside the stated range.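

In this assay, pyrrolidin-1-yl in place of dimethylamino on the core of compound 3 gave an at least 1.2-fold lower number from compound 3 to compound 4 (0.11 log units; that floor lies within the scatter). Compound 3 is known only as a limit, > 200000 nM. The result shows neither that the change carries over unaltered from one core to the other nor that the core alters its outcome: the same change on two cores in this assay, an at least 1.8-fold higher number (0.25 log units; that floor lies within the scatter) from compound 1 to compound 2 and an at least 1.2-fold lower number (0.11 log units; that floor lies within the scatter) from compound 3 to compound 4; the limit leaves it open whether they differ

The compounds shown leave open how a piperidin-1-yl or morpholin-4-yl group in the same place would read on either core, and how a longer chain carrying the amine would read. On these data alone, the part played by each bromine atom on its own also stays open.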